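This account rests on a few compounds, and the source may have more. Where it says the series, first, only, none or still open, it means among the compounds named here.

In a functional assay on HT-29 cells (Homo sapiens) for inhibition, read by CCK-8 assay, with a stated time of 24 h (on this read-out lower numbers stand for stronger inhibition and higher numbers for weaker inhibition), compound 1 (`Cc1ccc(-n2cc(-c3ccc(/C=C4\C(=O)Nc5ccc(F)cc54)cc3)nn2)cc1`) gives 3980 nM and compound 3 (`O=C1Nc2ccc(F)cc2/C1=C/c1ccc(-c2cn(-c3ccc(F)cc3)nn2)cc1`) gives 20000 nM as the higher of the two numbers. For compound 2 (`O=C1Nc2ccc(F)cc2/C1=C/c1ccc(-c2cn(-c3cccc(F)c3)nn2)cc1`) the result is a limit, > 12900 nM, and no number. Compound 4 (`O=C1Nc2ccc(F)cc2/C1=C/c1ccc(-c2cn(-c3ccc(Cl)c(C(F)(F)F)c3)nn2)cc1`) carries 4-chloro-3-(trifluoromethyl)phenyl in place of 4-fluorophenyl on an aromatic nitrogen. Two measured changes on that nitrogen bear on this: a 5.0-fold higher number from compound 1 to compound 3 (0.70 log units; beyond the scatter) and an at least 3.2-fold higher number from compound 1 to compound 2 (0.51 log units; beyond the scatter), both on leaving 4-methylphenyl. Compound 3 thus sits high, and a modest move to a lower number is expected. The expected change is a 2.5-fold lower number from compound 3 to compound 4 (0.40 log units; beyond the scatter) in this assay, though with low confidence. The estimate for compound 4 is 8000 nM, with an expected range from 2500 nM to 25000 nM on this read-out.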

Compound 4, half-maximal inhibitory concentration: 16500 nM
Compound 4: middle estimate off by 2.1-fold (0.31 log units), on the low side; measured number inside the range.
By their numbers in this assay, from the lowest: compound 1; then compounds 4 and 3 (each within the scatter of the next).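

In this assay, the heavier substitution on the aromatic nitrogen brings no readable change: a 1.2-fold lower number from compound 3 to compound 4 (0.08 log units; within the scatter). The 4-methylphenyl of compound 1 still stands apart, now from a second halogen-bearing ring, with a 4.1-fold higher number from compound 1 to compound 4 (0.62 log units; beyond the scatter). The steps involving compound 2 cannot be read, as its result is a limit: the limit of > 12900 nM in this assay, at which 1 of the 4 values shown sits.

On these data alone, it remains open whether the lower number of compound 1 belongs to the methyl group itself, or would also appear with 4-ethylphenyl or 4-methoxyphenyl. As far as these compounds go, the effect of an amine or a carboxylic acid on that phenyl ring also remains open.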